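Replacing the piperidin-4-yl group of compound 2

The source may report more compounds than this note shows. Statements on the series, on what has been measured and on what is new or still open speak of the compounds shown alone.

- compound 1 `c1cc([C@H]2CC[C@]3(CC2)OOC2(O3)C3CC4CC(C3)CC2C4)ccc1OCCOC1CCNCC1` gives 50 ug/mL
- compound 2 `c1cc([C@H]2CC[C@]3(CC2)OOC2(O3)C3CC4CC(C3)CC2C4)ccc1OCC1CCNCC1` gives 12.5 ug/mL

Both numbers come from a physicochemical assay for solubility, read by nephelometry, measured as kinetic solubility, with a stated time of 30 min (on this read-out lower numbers stand for lower solubility and higher numbers for higher solubility), and compound 2 holds the lower of the two, with compound 1 standing above it. Compound 3 `NCCCCOc1ccc([C@H]2CC[C@]3(CC2)OOC2(O3)C3CC4CC(C3)CC2C4)cc1` keeps the core of compound 2 and alters only the side chain, where 3-aminopropyl in place of piperidin-4-yl on a saturated chain carbon bound to an oxygen on an aromatic ring places 3-aminopropyl in place of piperidin-4-yl on a saturated chain carbon bound to an oxygen on an aromatic ring. Among the compounds with values here, no measured step covers this exchange. The nearest evidence is a 4.0-fold lower number from compound 1 to compound 2 (0.60 log units; beyond the scatter) as a modest change beyond the scatter, made at the same place with piperidin-4-yl in place of ((piperidin-4-yl)oxy)methyl. That step shows that the number can move with this side chain, but it does not fix a direction for the new exchange. With so little evidence, only a small upward change is expected in this assay and no larger than the measured step. The estimated change is a 2.0-fold higher number from compound 2 to compound 3 (0.30 log units; within the scatter) on this reading. Compound 3 is expected at 25 ug/mL within an estimated range of 10 ug/mL to 60 ug/mL in this assay when it is measured.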

Compound 3, solubility: 50 ug/mL
For compound 3 the middle estimate is 2.0-fold (0.30 log units) below the measured one, within the range that was stated.
By their numbers in this assay, from the lowest: compound 2; then compounds 1 and 3 (each within the scatter of the next).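

In this assay the exchange of piperidin-4-yl for 3-aminopropyl gives a 4.0-fold higher number from compound 2 to compound 3 (0.60 log units; beyond the scatter) and shows that this place, on a saturated chain carbon bound to an oxygen on an aromatic ring, can carry a side chain with no ring at all, which the earlier pair, both with a six-membered non-aromatic ring, could not show. The comparison with the longer ring-bearing side chain reads no change at the digits printed from compound 1 to compound 3 (within the scatter) and so places compound 3, with its open chain, level with compound 1, with its ring, leaving compound 2 as the only one of the three set apart by steps beyond the scatter; the presence of a ring in the side chain therefore does not by itself decide the number among these compounds. Nothing shown here gives a measured reason for the way the number moves with these side chains.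

What the compounds shown leave open is how a chain ending in a tertiary amine or a carboxylic acid would read at this place in this assay and whether a longer chain ending in a primary amine would stay level with compound 3. They also leave open whether a piperidine joined through its nitrogen would read like compound 2 or like compound 1.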